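Shortening the Linker by One Carbon in a Hydroxamate

A few compounds are considered here, and "the series" means these few. Any claim that something is new, unique, unknown or untested is made for them only; others in the source may bear on it.

In an assay on isolated protein for inhibition of histone deacetylase 8 (Homo sapiens), read by fluorescence (on this read-out higher numbers stand for weaker inhibition and lower numbers for stronger inhibition), compound 1 `C#CCN(C)CCCOc1cc(NCc2ccc(/C=C/C(=O)NO)cc2)ccc1Cl` gives 80 nM. Compound 2 `C#CCN(C)CCCOc1cc(NC(=O)CCCCCCCCC(=O)NO)ccc1Cl` shares the same left-hand portion but carries a long saturated chain between the amide on the ring and the hydroxamic acid; in this assay compound 2 gives 2480 nM, the higher of the two numbers and therefore the weaker inhibitor, with the gap to compound 1 lying beyond the usual scatter.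

Compound 3 `C#CCN(C)CCCOc1cc(NC(=O)CCCCCCCC(=O)NO)ccc1Cl` is the same chain made one carbon shorter: hydroxycarbamoyl in place of (hydroxycarbamoyl)methyl on a saturated chain carbon, seven bonds along the chain from a carbonyl carbon. Within the data shown here, no measured pair in this set shows what such a shortening does, so the expectation rests only on the values shown and on the change itself. Trimming a flexible chain by one carbon is a small change, and the step from compound 2 to compound 3 is expected to be modest, most likely towards somewhat stronger inhibition, as a 1.7-fold lower number from compound 2 to compound 3 (0.22 log units; within the scatter). Compound 3 is accordingly estimated to give 1500 nM in this assay, with a plausible range from 500 nM to 5000 nM.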

Compound 3, half-maximal inhibitory concentration: 1120 nM
For compound 3 the middle estimate is 1.3-fold (0.13 log units) above the measured one; the measured number falls inside the stated range.
By their numbers in this assay, from the lowest: compound 1; then compound 3; then compound 2.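

Among these compounds, compound 3 gives the first direct reading of chain length. In this assay, shortening the chain gives a 2.2-fold lower number from compound 2 to compound 3 (0.35 log units; beyond the scatter) and shows that this end of the molecule responds to a small trim, with the rest of the structure left unchanged. The step is modest but lies beyond the usual scatter, so shortening the chain here gives a real, if limited, gain in inhibition, and no measurement shown here accounts for it.

A single step fixes only two points on the chain-length scale, so it cannot show whether a still shorter chain would strengthen inhibition further, level off or reverse the gain. Nor can it show how much depends on the hydroxamic acid itself, a question that a carboxylic acid at the end of the same chain would put to the test.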